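The compounds below may be only part of what the source reports. "The series", "measured", "known", "first", "only" and "open" are said of these compounds alone.

In an ADME assay on the whole organism (Rattus norvegicus, strain Sprague-Dawley) for pharmacokinetics, read by LC-MS, with a stated time of 30 min (on this read-out lower numbers stand for narrower distribution and higher numbers for wider distribution into tissues), compound 1 (`N#Cc1ccc(O[C@H]2CN(S(=O)(=O)c3ccc(Cl)cc3Cl)C[C@@]2(O)CO)cc1F`) gives 54 L/kg and compound 2 (`N#Cc1ccc(O[C@H]2CN(S(=O)(=O)c3ccc(C(F)(F)F)cc3C#N)C[C@@]2(O)CO)cc1F`) gives 73 L/kg and so stands within the usual scatter of compound 1. Compound 3 (`N#Cc1ccc(O[C@H]2CN(S(=O)(=O)c3ccccc3C#N)C[C@@]2(O)CO)cc1F`) has hydrogen in place of trifluoromethyl on an aromatic carbon of compound 2 (hydrogen in place of trifluoromethyl on an aromatic carbon). Among the measured compounds shown here, no measured pair of compounds differs in one place only, so nothing measured sets the size of this step. The expected change in this assay is a moderate fall, estimated as a 2.1-fold lower number from compound 2 to compound 3 (0.32 log units; beyond the scatter) and close to the edge of the usual scatter. For compound 3 the estimated value is 35 L/kg (expected range 14 L/kg to 80 L/kg).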

Compound 3, volume of distribution at steady state: 4.6 L/kg
Compound 3: middle estimate off by 7.6-fold (0.88 log units), on the high side; the measured number lies below the stated range.
By their numbers in this assay, from the lowest: compound 3; then compounds 1 and 2 (each within the scatter of the next).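

Hydrogen in place of trifluoromethyl on this aromatic carbon brings a 16-fold lower number from compound 2 to compound 3 (1.20 log units; beyond the scatter) in this assay, so a single change at this place can move the read-out far beyond the scatter. 2-Cyanophenyl in place of 2,4-dichlorophenyl on the sulfonyl sulfur brings a fall of similar kind, a 12-fold lower number from compound 1 to compound 3 (1.07 log units; beyond the scatter), and of the three compounds only compound 3 carries hydrogen at this place. Nothing measured here explains the fall. Going by these compounds, whether methyl, methoxy or an amine on this carbon would keep the higher number or land nearer compound 3 stays open.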